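This account rests on a few compounds, and the source may have more. Where it says the series, first, only, none or still open, it means among the compounds named here.

Measured compounds:
compound 1 `COc1ccc(/C=C/C(=O)/C=C/c2ccc(OCc3cn(CCCCCOc4cc(=O)oc5ccccc45)nn3)c(OC)c2)cc1OC` gives 47% in a functional assay on THP-1 cells (Homo sapiens) for inhibition, read by sulforhodamine B assay, with a stated time of 48 h, tested at 50 uM; on this read-out lower numbers stand for less inhibition of growth and higher numbers for more inhibition of growth at the one concentration tested
compound 2 `COc1ccc(/C=C/C(=O)/C=C/c2ccc(OCc3cn(CCOc4cc(=O)oc5ccccc45)nn3)c(OC)c2)cc1OC` gives 90% in this assay
compound 3 `COc1cc(/C=C/C(=O)/C=C/c2ccccc2)ccc1OCc1cn(CCCCCOc2cc(=O)oc3ccccc23)nn1` gives 26% in this assay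

Compound 2 stands highest of the three, beyond the scatter from both others. The cores of compound 1 and compound 2 differ, but that difference is not broken down here. Compound 3 arises from compound 1 by phenyl in place of 3,4-dimethoxyphenyl on a double-bonded chain carbon bound to a double-bonded chain carbon, and this gave the step of a number 21 percentage points lower from compound 1 to compound 3 (beyond the scatter). Compound 4 `COc1cc(/C=C/C(=O)/C=C/c2ccccc2)ccc1OCc1cn(CCOc2cc(=O)oc3ccccc23)nn1` is not yet measured in this assay; it arises from compound 2 by phenyl in place of 3,4-dimethoxyphenyl on a double-bonded chain carbon bound to a double-bonded chain carbon, the same change at the same place. Compound 4 is expected to lose ground by a step of about a number 22 percentage points lower from compound 2 to compound 4 (beyond the scatter). This expectation rests on a single prior observation, the step of a number 21 percentage points lower from compound 1 to compound 3 (beyond the scatter), so the range is kept wide. The estimate for compound 4 is 68%, between 45% and 85%.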

Compound 4, percent growth inhibition at one concentration: 61%
Compound 4: middle estimate off by 7 percentage points, on the high side, within the range that was stated.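

The step of a number 29 percentage points lower from compound 2 to compound 4 (beyond the scatter) in this assay comes with phenyl in place of 3,4-dimethoxyphenyl, the same direction as on the core of compound 1. Two pairs on two cores do not show that the change carries over to any further core, and they give no reason for the loss of growth inhibition. Within these two cores, the change carries over in direction and in size: the same change on two cores in this assay, a number 21 percentage points lower (beyond the scatter) from compound 1 to compound 3 and a number 29 percentage points lower (beyond the scatter) from compound 2 to compound 4, 8 percentage points apart, within the scatter of two such steps

Still open, going by these compounds, is whether a phenyl bearing an amine or a carboxylic acid at this place follows the same step. Also open, on these data alone, is whether the step holds on a core with a longer chain.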